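Free fraction notes: compound 3 to compound 4

This account rests on a few compounds, and the source may have more. Where it says the series, first, only, none or still open, it means among the compounds named here.

In an ADME assay on the whole organism (plasma, Rattus norvegicus) for protein binding, using cassette dosing, at a dose of 1 mg/kg (on this read-out higher numbers stand for a larger free fraction and lower numbers for a smaller free fraction), compound 1 (`CC(C)Oc1ccc(/N=c2\[nH]c(=O)n(C[C@@H](C)C(=O)O)c(=O)n2Cc2ccc(Cl)cc2)cc1Cl`) gives 0.002, compound 2 (`C[C@@H](Cn1c(=O)[nH]/c(=N\c2ccc(Oc3nccs3)cc2)n(Cc2ccc(Cl)cc2)c1=O)C(=O)O`) gives 0.006 and compound 3 (`C[C@@H](Cn1c(=O)[nH]/c(=N\c2ccc(Oc3cccc(F)n3)cc2)n(Cc2ccc(Cl)cc2)c1=O)C(=O)O`) gives 0.007. Compound 3 thus stands clear of compound 1 but not of compound 2. Compound 4 (`C[C@@H](Cn1c(=O)[nH]/c(=N\c2ccc(Oc3ccsn3)cc2)n(Cc2ccc(Cl)cc2)c1=O)C(=O)O`) carries 1,2-thiazol-3-yl in place of 6-fluoropyridin-2-yl on an oxygen on an aromatic ring. Among the compounds with values here, the one measured step at this place, a 1.2-fold higher number from compound 2 to compound 3 (0.07 log units; within the scatter), exchanged 1,3-thiazol-2-yl for 6-fluoropyridin-2-yl and stayed within the scatter. No shift beyond the scatter is therefore expected in this assay. The expected change is a 1.2-fold lower number from compound 3 to compound 4 (0.07 log units; within the scatter). The estimate for compound 4 is 0.006, with an expected range of 0.003 to 0.012.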

Compound 4, unbound fraction: 0.012
For compound 4 the middle estimate is 2.0-fold (0.30 log units) below the measured one, within the range that was stated.
By their numbers in this assay, from the lowest: compound 1; then compounds 2, 3 and 4 (each within the scatter of the next).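

In this assay, 1,2-thiazol-3-yl on an oxygen on an aromatic ring gives a 1.7-fold higher number from compound 3 to compound 4 (0.23 log units; within the scatter) and also a 2.0-fold higher number from compound 2 to compound 4 (0.30 log units; within the scatter), the second step being against 1,3-thiazol-2-yl. Compounds 2, 3 and 4 therefore stay within the scatter of one another across a five-membered and a six-membered aromatic ring, and across two placements of the hetero atoms in the five-membered ring. No measurement here accounts for these numbers.

Going by these compounds, whether an amine or a carboxylic acid carried on this ring would move the free fraction beyond the scatter stays open.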